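The source may hold more compounds than are shown below. What is called first, only, known or untested is meant among the compounds shown, and "the series" means these compounds.

Going by the values given here, in an ADME assay on L6 cells (Rattus norvegicus) for cytotoxicity, read by resazurin assay, with a stated time of 70 h (on this read-out lower numbers stand for stronger inhibition and higher numbers for weaker inhibition), three compounds built on one shared core have numbers so far: compound 1 (`CC(=O)Oc1ccc2c(c1)C(C)=CC(C)(C)N2Cc1ccc(Cl)cc1`) gives 22000 nM, compound 2 (`CC(=O)Oc1ccc2c(c1)C(C)=CC(C)(C)N2Cc1ccc(C)cc1`) gives 21000 nM, and compound 3 (`CC(=O)Oc1ccc2c(c1)C(C)=CC(C)(C)N2Cc1cccc(Cl)c1`) gives 29000 nM. Compound 3 thus stands level with the other two, within the usual scatter of repeated measurements. Compound 4 (`CC(=O)Oc1ccc2c(c1)C(C)=CC(C)(C)N2Cc1ccc(F)cc1`) changes one group of compound 3: 4-fluorophenyl in place of 3-chlorophenyl on a saturated chain carbon bound to a nitrogen on an aromatic ring in a ring. Among the compounds with values here, three measured steps bear on this change, all within the scatter: a 1.0-fold lower number from compound 1 to compound 2 (0.02 log units; within the scatter), a 1.3-fold higher number from compound 1 to compound 3 (0.12 log units; within the scatter) and a 1.4-fold higher number from compound 2 to compound 3 (0.14 log units; within the scatter). Since swaps on this same ring moved the number so little, no step beyond the scatter is expected in this assay. The expected change is a 1.2-fold lower number from compound 3 to compound 4 (0.08 log units; within the scatter). Compound 4 is estimated at 24000 nM, with an expected range of 13000 nM to 42000 nM.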

Compound 4, half-maximal inhibitory concentration: 29000 nM
Beside the measured number, compound 4's estimate is 1.2-fold (0.08 log units) below it; low and high end bracket the measured number.
By their numbers in this assay, from the lowest: compounds 2, 1, 3 and 4 (each within the scatter of the next).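

In this assay, 4-fluorophenyl in place of 3-chlorophenyl gives a result (no change at the digits printed from compound 3 to compound 4 (within the scatter)) showing that changing both the halogen and where it sits leaves the read-out level. Fluoro in place of methyl (a 1.4-fold higher number from compound 2 to compound 4 (0.14 log units; within the scatter)) and fluoro in place of chloro (a 1.3-fold higher number from compound 1 to compound 4 (0.12 log units; within the scatter)) add a third small group to this flat picture. No evidence at hand explains this flatness. Still open, as far as these compounds go, is whether an amine or a carboxylic acid on this ring would give a step beyond the scatter.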